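The compounds below may be only part of what the source reports. "The series", "measured", "known", "first", "only" and "open" are said of these compounds alone.

Of the compounds shown here, two have been measured so far, compound 1 `N/C(=N\NC(=S)N1CCN(c2ccccn2)CC1)c1ccc(F)cn1` and compound 2 `Cc1ccnc(/C(N)=N/NC(=S)N2CCOCC2)c1`, which share a core. In a functional assay on A-431 cells (Homo sapiens) for cytotoxicity, read by MTT assay, with a stated time of 72 h, tested at 3 uM (on this read-out higher numbers stand for more inhibition of growth at the one concentration tested and lower numbers for less inhibition of growth), compound 1 gives 43%, and in this assay compound 2 gives 35.5%. Among the compounds with values here, the gap between these two numbers lies within the usual scatter of repeated measurements, so neither compound can be set apart from the other on this read-out; compound 1 is simply the one whose number is used as the starting point here.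

Compound 3 `N/C(=N\NC(=S)N1CCN(c2ccccn2)CC1)c1ccccn1` has not yet been measured. It differs from compound 1 in one place: hydrogen in place of fluoro on an aromatic carbon. Within the data shown here, no two measured compounds differ from each other in a single place, so there is no measured step to lean on for this kind of change. Only one heavy atom, a fluorine, leaves, and a hydrogen atom takes its place, so in this assay the step of a number 3 percentage points lower from compound 1 to compound 3 (within the scatter) is expected, that is, none beyond the scatter in either direction. Compound 3 is therefore estimated to give about 40% in this assay, most likely between 25% and 55%.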

Compound 3, percent growth inhibition at one concentration: 45.8%
Beside the measured number, compound 3's estimate is 5.8 percentage points below it; low and high end bracket the measured number.
By their numbers in this assay, from the lowest: compounds 2, 1 and 3 (each within the scatter of the next, the first and the last beyond it).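

Within the data shown here, this is the first step that changes only one place, and it concerns the fluoro on an aromatic carbon, two atoms from the ring nitrogen. In this assay, going from 5-fluoropyridin-2-yl to pyridin-2-yl gives a number 2.8 percentage points higher from compound 1 to compound 3 (within the scatter), so at this position the fluorine can be replaced by hydrogen without a difference that this read-out can detect, at least at the one concentration tested. Nothing available here speaks to why the two compounds cannot be told apart.

The compounds shown carry only fluoro or hydrogen at this position, so it remains open whether another group there, such as an amine, a methoxy group or a carboxylic acid, would move the number beyond the scatter in either direction. As far as these compounds go, it also remains open whether the same swap would look alike with a different group at the other end of the molecule, or at a concentration other than the single one used here.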